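The source may hold more compounds than are shown below. What is called first, only, known or untested is meant among the compounds shown, and "the series" means these compounds.

Compound 1 `CC(C)(C)Sc1c(CC(C)(C)C(=O)O)n(Cc2ccc(Cl)cc2)c2ccc(OCc3ccc4cc(F)c(F)cc4n3)cc12` gives 7 nM in a functional assay for inhibition, with Homo sapiens as the target; on this read-out lower numbers stand for stronger inhibition and higher numbers for weaker inhibition. Compound 2 `CC(C)(C)Sc1c(CC(C)(C)C(=O)O)n(Cc2ccc(Cl)cc2)c2ccc(OCc3ccc4cccnc4n3)cc12` gives 6 nM in this assay, and the step of a 1.2-fold lower number from compound 1 to compound 2 (0.07 log units; within the scatter) sits within the scatter. Compound 3 `CC(C)(C)Sc1c(CC(C)(C)C(=O)O)n(Cc2ccc(Cl)cc2)c2ccc(OCc3nc4ccccc4o3)cc12` in this assay returns only a limit, < 7 nM. The steps of a number no higher from compound 1 to compound 3 (the limit leaves the size open) and a step that the limit leaves unreadable from compound 2 to compound 3 are therefore of unreadable size, as the limit of < 7 nM in this assay, at which 1 of the 3 values shown sits, records. Compound 4 `CC(C)(C)Sc1c(CC(C)(C)C(=O)O)n(Cc2ccc(Cl)cc2)c2ccc(OCc3cnccn3)cc12` differs from compound 3 by pyrazin-2-yl in place of 1,3-benzoxazol-2-yl on a saturated chain carbon bound to an oxygen on an aromatic ring. Within the data shown here, the measured steps all exchange one two-ring group for another at the same place and stay within the scatter or end at the limit; none of them trades a two-ring group for a single six-membered ring, so no measured step bears directly on this change, and the starting point itself is only a limit. Among the measured compounds shown here, compound 4 is thus expected to show a step of an at least 2.8-fold higher number from compound 3 to compound 4 (0.45 log units; beyond the scatter) that rests on no measured precedent and is taken as a moderate loss with wide uncertainty. Compound 4 is estimated at 20 nM in this assay, with a range from 5 nM to 80 nM.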

Compound 4, half-maximal inhibitory concentration: 4 nM
Compound 4: middle estimate off by 5.0-fold (0.70 log units), on the high side; measured number outside the range, below it.
By their numbers in this assay, from the lowest: compounds 4, 2 and 1 (each within the scatter of the next).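

In this assay the single six-membered ring of pyrazin-2-yl, on a saturated chain carbon bound to an oxygen on an aromatic ring, does as well as either two-ring group within the scatter (a 1.5-fold lower number from compound 2 to compound 4 (0.18 log units; within the scatter)) and (a 1.8-fold lower number from compound 1 to compound 4 (0.24 log units; within the scatter)). Among compounds 1, 2 and 4, a second ring at this place is therefore not needed to hold the value, and the heavy-atom count of the group can shrink with no change beyond the scatter. Compound 3 returns only a limit, so its step to compound 4 cannot be read: the limit of < 7 nM in this assay, at which 1 of the 4 values shown sits.

Whether the ring nitrogens of pyrazin-2-yl matter stays open, as a phenyl ring of carbon only is not among the compounds shown. Also open, going by these compounds, is whether an amine or a simple alkyl chain in place of the ring would hold the value.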